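A Chloro-to-Fluoro Swap Repeated on a Second Core

The source may report more compounds than this note shows. Statements on the series, on what has been measured and on what is new or still open speak of the compounds shown alone.

Compound 1 `N#Cc1c(F)c(Cl)c(C(C(=O)c2ccc(Cl)cc2)=C2NCCN2)c(C#N)c1F` and compound 2 `N#Cc1c(F)c(F)c(C(C(=O)c2ccc(Cl)cc2)=C2NCCN2)c(C#N)c1F` share one core and differ in a single substituent. In a functional assay on HL-60 cells (Homo sapiens) for antiproliferative activity, read by MTT assay (a higher number here means a weaker inhibitor, a lower number a stronger inhibitor), compound 1 gives 0.3 ug/mL, and compound 2 gives 0.3 ug/mL. The change between them is fluoro in place of chloro on an aromatic carbon, and it made no change at the digits printed from compound 1 to compound 2 (within the scatter).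

Compound 3 `N#Cc1c(F)c(Cl)c(C(C(=O)c2ccc(F)cc2)=C2NCCCN2)c(C#N)c1F` is built on a different core; the difference between the core of compound 1 and the core of compound 3 is not broken down here. In this assay compound 3 gives 0.6 ug/mL, a value that lies within the scatter of those of compound 1 and compound 2.

Compound 4 `N#Cc1c(F)c(F)c(C(C(=O)c2ccc(F)cc2)=C2NCCCN2)c(C#N)c1F` has not yet been measured. Going by the values given here, it differs from compound 3 by fluoro in place of chloro on an aromatic carbon, which is the same change as the one from compound 1 to compound 2, at a place described in the same words. Because the earlier step was no change at the digits printed from compound 1 to compound 2 (within the scatter), this change is expected to make no change at the digits printed from compound 3 to compound 4 (within the scatter). Compound 4 is therefore estimated to give 0.6 ug/mL in this assay, with a likely range from 0.3 ug/mL to 1.2 ug/mL.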

Compound 4, half-maximal inhibitory concentration: 0.04 ug/mL
Estimate against measurement, compound 4: 15-fold (1.18 log units) above; the measured number lies below the stated range.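

In this assay, the swap of fluoro for chloro on an aromatic carbon did not carry over from one core to the other, and the two steps must be read as different: the same change on two cores in this assay, no change at the digits printed (within the scatter) from compound 1 to compound 2 and a 15-fold lower number (1.18 log units; beyond the scatter) from compound 3 to compound 4, 15-fold (1.18 log units) apart, beyond the scatter of two such steps On the core of compound 3, the swap gave a 15-fold lower number from compound 3 to compound 4 (1.18 log units; beyond the scatter), whereas the same swap on the core of compound 1 gave no change at the digits printed from compound 1 to compound 2 (within the scatter), so the outcome of this change in this series depends on the core that carries it. This does not show which feature of the two cores is responsible, and with one pair on each core it gives no rule for any further core.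

From the compounds shown here alone, whether a third core would follow the pattern of compound 1 and compound 2 or that of compound 3 and compound 4 remains open. Going by these compounds, it is also open how bromo, methoxy or an amine at the same place would compare with chloro and fluoro on either core.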